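This account rests on a few compounds, and the source may have more. Where it says the series, first, only, none or still open, it means among the compounds named here.

Series notes. In a functional assay on HeLa cells (Homo sapiens) for inhibition, read by MTT assay, with a stated time of 48 h (a higher number here means a weaker inhibitor, a lower number a stronger inhibitor), compound 1, `O=C1CN(C2CCCC2)c2nc(Nc3ccc(N4CCCCC4)cc3)ncc2N1`, gives only a limit, > 30000 nM. Compound 2, `CN1CCN(c2ccc(Nc3ncc4c(n3)N(C3CCCC3)CC(=O)N4)nc2)CC1`, likewise gives only a limit in this assay, > 30000 nM. Compound 3, `O=C1CN(C2CCCC2)c2nc(Nc3ccc(N4CCCCC4)cn3)ncc2N1`, also gives only a limit in this assay, > 30000 nM. For the measured compounds named here, compound 3 thus stands at the limit with the other two, and the one step that connects two measured compounds, a step that the two limits leave unreadable from compound 2 to compound 3, cannot be sized. the limit of > 30000 nM in this assay, at which 3 of the 3 values shown sit, is the whole of the measured evidence: no step has a readable size or direction.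

Compound 4, `CC1CCN(c2ccc(Nc3ncc4c(n3)N(C3CCCC3)CC(=O)N4)nc2)CC1`, differs from compound 3 by methyl in place of hydrogen on a saturated ring carbon. Going by the values given here, no measured step concerns a change at a saturated ring carbon, and the single step available is unreadable, so nothing here supplies a size or a direction for this change. In this assay compound 4 is therefore expected, most probably, to be reported again only as a limit. The expected step for compound 4 is a step that the limit leaves unreadable from compound 3 to compound 4, no shift beyond the scatter. The estimate for compound 4 in this assay is 50000 nM, with a range from 15000 nM to 200000 nM.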

Compound 4, half-maximal inhibitory concentration: > 30000 nM
Compound 4: only a limit was reported; the forecaster's own chance of this, stated with the estimate: 85%; the middle value is on the limit's open side.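

Compound 4 also gives only a limit in this assay, > 30000 nM, so the steps linking compound 2, compound 3 and compound 4 cannot be read, in size or direction: the limit of > 30000 nM in this assay, at which 4 of the 4 values shown sit.

The compounds shown leave open which change, if any, would bring a measurable value in this series.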